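Chloro on the benzylamino group of compound 2

This account rests on a few compounds, and the source may have more. Where it says the series, first, only, none or still open, it means among the compounds named here.

Series notes. In an assay on HEK293 cells for inhibition of nuclear factor NF-kappa-B complex (Homo sapiens), read by a luciferase reporter, with stated times of 1 h and 3 h (on this read-out lower numbers stand for stronger inhibition and higher numbers for weaker inhibition), compound 2 `CC(C)(C)CNC(=O)C[C@H](NC(=O)c1ccc(OCc2ccccc2)cc1)C(=O)N[C@@H](CCc1ccccc1)C(=O)NCc1ccccc1` gives 22 nM. Compound 3 `CC(C)(C)CNC(=O)C[C@H](NC(=O)C(=O)c1c[nH]c2ccccc12)C(=O)N[C@@H](CCc1ccccc1)C(=O)NCc1ccccc1` gives 25 nM and compound 1 `CC(C)(C)CNC(=O)C[C@H](NC(=O)c1ccc(C(C)(C)C)cc1)C(=O)N[C@@H](CCc1ccccc1)C(=O)NCc1ccccc1` gives 32 nM; all three numbers sit within the scatter of one another, so none separates from the rest. The measured steps, a 1.5-fold lower number from compound 1 to compound 2 (0.16 log units; within the scatter) and a 1.3-fold lower number from compound 1 to compound 3 (0.11 log units; within the scatter), both concern the other end of the shared core, and neither crossed the scatter. Compound 4 `CC(C)(C)CNC(=O)C[C@H](NC(=O)c1ccc(OCc2ccccc2)cc1)C(=O)N[C@@H](CCc1ccccc1)C(=O)NCc1ccccc1Cl` differs from compound 2 by chloro in place of hydrogen on an aromatic carbon. Among the compounds with values here, no measured step touches the benzylamino group, so nothing bears directly on this change; the expectation defaults to a step no larger than the scatter, that is a 1.1-fold lower number from compound 2 to compound 4 (0.04 log units; within the scatter). Compound 4 is thus estimated at 20 nM in this assay, with a range of 8 nM to 50 nM.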

Compound 4, half-maximal inhibitory concentration: 39 nM
The estimate for compound 4 lay 2.0-fold (0.29 log units) below the measured number; low and high end bracket the measured number.
By their numbers in this assay, from the lowest: compounds 2, 3, 1 and 4 (each within the scatter of the next).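

In this assay, within the data shown here, the first measured change on the benzylamino group, (2-chlorobenzyl)amino in place of benzylamino, gives a 1.8-fold higher number from compound 2 to compound 4 (0.25 log units; within the scatter). Chloro on an aromatic carbon, ortho to a large group, therefore keeps compound 4 within the scatter of compound 2, and this position now has a measured step. Nothing available bears on what lies behind this small step.

Going by these compounds, whether an amine, a carboxylic acid or a methoxy group at this place would give a step beyond the scatter stays open. So does the outcome of a longer chain in place of benzyl.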